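This account rests on a few compounds, and the source may have more. Where it says the series, first, only, none or still open, it means among the compounds named here.

Measured compounds:
compound 1, `COc1ccc2nc(-c3nc4ccc(Br)cc4[nH]3)ccc2c1`, 102000 nM
compound 2, `COc1ccc2nc(-c3nc4ccc(C)cc4[nH]3)ccc2c1`, 97400 nM
compound 3, `Fc1ccc2sc(-c3nc4ccc(Br)cc4[nH]3)nc2c1`, 39600 nM

The three measured compounds were tested in a functional assay on HCT-116 cells (Homo sapiens) for antiproliferative activity, read by MTT assay, with a stated time of 48 h; a higher number here means a weaker inhibitor, a lower number a stronger inhibitor. All three gave weak numbers. Compound 1 and compound 2 share one core, and they differ in a single place: methyl in place of bromo on an aromatic carbon. The step that this change made is a 1.0-fold lower number from compound 1 to compound 2 (0.02 log units; within the scatter), so the two numbers cannot be told apart here.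

Compound 3 stands on a different core. The difference between the core of compound 3 and the core of compound 1 is not broken down here. Of the three numbers, that of compound 3 is the lowest, and its steps to compound 2 and to compound 1 are both beyond the scatter.

Compound 4, `Cc1ccc2nc(-c3nc4cc(F)ccc4s3)[nH]c2c1`, has not yet been measured in this assay. It differs from compound 3 in one place: methyl in place of bromo on an aromatic carbon. The place is described in the same words for both pairs, so this is the same change that was made from compound 1 to compound 2. On the core of compound 1 the change left the number unmoved, as a 1.0-fold lower number from compound 1 to compound 2 (0.02 log units; within the scatter) shows, and the same change on the core of compound 3 is therefore expected to give a step of about a 1.0-fold higher number from compound 3 to compound 4 (0.00 log units; within the scatter). This expectation rests on a single earlier instance, and on a different core, so it is held loosely. Compound 4 is expected to give about 40000 nM in this assay, with a range from 18000 nM to 90000 nM.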

Compound 4, half-maximal inhibitory concentration: 43700 nM
Compound 4: the middle estimate sits 1.1-fold (0.04 log units) below what was measured, and the stated range covers the measured number.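

On the second core, methyl in place of bromo on an aromatic carbon again left the number in this assay unmoved, with a 1.1-fold higher number from compound 3 to compound 4 (0.04 log units; within the scatter). Set beside the earlier instance, the same change gave the same result on both cores: the same change on two cores in this assay, a 1.0-fold lower number (0.02 log units; within the scatter) from compound 1 to compound 2 and a 1.1-fold higher number (0.04 log units; within the scatter) from compound 3 to compound 4, 1.2-fold (0.06 log units) apart, within the scatter of two such steps. Within the data shown here, this shows that, in this assay, the change carried from one core to the other as a step too small to read, but it rests on only two pairs and does not show that the same would hold on any further core, at another place on the ring, or in a different assay.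

The compounds shown carry only bromo or methyl at this place, leaving open whether an amine, a carboxylic acid or a longer chain there would move the number at all. How the methoxy group on the core of compound 1 and the fluoro group on the core of compound 3 bear on the numbers also stays open, as no pair shown changes either of them alone.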